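The source may hold more compounds than are shown below. What is called first, only, known or untested is meant among the compounds shown, and "the series" means these compounds.

Measured so far:
compound 1 `Cn1ncc2c(-c3ccccc3)cc(NNC(=O)Nc3cc(Cl)nc(Cl)c3)nc21`: 1020 nM
compound 2 `COc1ccc(-c2cc(NNC(=O)Nc3cc(Cl)nc(OC)c3)nc3c2cnn3C)cc1`: 1980 nM
compound 3 `COc1ccc(-c2cc(NNC(=O)Nc3cc(Cl)nc(Cl)c3)nc3c2cnn3C)cc1`: 520 nM

These three compounds share a core and were tested in an assay on isolated protein for binding affinity to sphingosine 1-phosphate receptor 2 (Homo sapiens), read by surface plasmon resonance; on this read-out lower numbers stand for tighter binding and higher numbers for weaker binding. Compound 3 holds the lowest number of the three; compound 1 lies nearest, and that gap, a 2.0-fold lower number from compound 1 to compound 3 (0.29 log units; within the scatter), falls within the scatter, so the two cannot be ordered. Compound 2 lies furthest, and the step of a 3.8-fold lower number from compound 2 to compound 3 (0.58 log units; beyond the scatter) is a modest one beyond the scatter.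

Compound 4 `CCCOc1cc(NC(=O)NNc2cc(-c3ccc(OC)cc3)c3cnn(C)c3n2)cc(Cl)n1` has not yet been tested. It differs from compound 3 in one place: propoxy in place of chloro on an aromatic carbon. The step that bears on this change is a 3.8-fold lower number from compound 2 to compound 3 (0.58 log units; beyond the scatter), where an alkoxy group was replaced by chloro and the number fell. The change from compound 3 to compound 4 runs the other way, an alkoxy group entering where chloro stood, so the account expects the number to rise by a comparable, modest amount, a 3.5-fold higher number from compound 3 to compound 4 (0.54 log units; beyond the scatter). Compound 4 is therefore estimated at 1800 nM, with a range from 700 nM to 4500 nM.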

Compound 4, dissociation constant: 3140 nM
Beside the measured number, compound 4's estimate is 1.7-fold (0.24 log units) below it; the measured number falls inside the stated range.
By their numbers in this assay, from the lowest: compounds 3, 1, 2 and 4 (each within the scatter of the next, the first and the last beyond it).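

At this position, next to the ring nitrogen, propoxy in place of chloro gives a 6.0-fold higher number from compound 3 to compound 4 (0.78 log units; beyond the scatter), so the rise in the number seen earlier with methoxy also appears with a longer alkoxy group. Extending the chain from methoxy to propoxy gives a 1.6-fold higher number from compound 2 to compound 4 (0.20 log units; within the scatter), so compound 2 and compound 4 cannot be ordered, and over this span the chain length does not separate them, leaving chloro as the substituent with the lower number in this comparison. Nothing shown here gives a reason for this difference.

The compounds shown leave open how an amine, a bromo group or a plain hydrogen at this position would compare with chloro. They also leave open whether a chain longer than propoxy would stay level with these two alkoxy compounds.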